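Inverting one stereocentre of compound 3

This account rests on a few compounds, and the source may have more. Where it says the series, first, only, none or still open, it means among the compounds named here.

Compound 1 `CCCCCCCCCCCCCC[C@@H]1N[C@@H](CO)[C@@H]1O` gives 0.56 ug/mL
Compound 2 `CCCCCCCCCCCCCC[C@@H]1N[C@H](CO)[C@H]1O` gives 0.79 ug/mL
Compound 3 `CCCCCCCCCCCCCC[C@H]1N[C@@H](CO)[C@@H]1O` gives 0.17 ug/mL
Compound 4 `CCCCCCCCCCCCCC[C@H]1N[C@@H](CO)[C@H]1O` is not yet measured

In a functional assay on HT529 cells (Homo sapiens) for cytotoxicity (a higher number here means a weaker inhibitor, a lower number a stronger inhibitor), compound 3 gives the lowest number of the three (0.17 ug/mL) and lies beyond the scatter of both others (a 3.3-fold lower number from compound 1 to compound 3 (0.52 log units; beyond the scatter); a 4.6-fold lower number from compound 2 to compound 3 (0.67 log units; beyond the scatter)). Compound 4 comes from it by one change (the two compounds have the same atoms and bonds and differ only in configuration as drawn: 1 of 3 stereo elements differ; a stereocentre at a saturated ring carbon is drawn R in compound 3 and S in compound 4). For the measured compounds named here, the only measured step that also inverts a single stereocentre is modest (a 3.3-fold lower number from compound 1 to compound 3 (0.52 log units; beyond the scatter)), while the inversion of two stereocentres stays within the scatter (a 1.4-fold higher number from compound 1 to compound 2 (0.15 log units; within the scatter)). With compound 3 lowest so far, a modest rise in the number is expected (a 2.1-fold higher number from compound 3 to compound 4 (0.31 log units; beyond the scatter)). Compound 4 is estimated at 0.35 ug/mL (expected range 0.12 ug/mL to 0.9 ug/mL).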

Compound 4, half-maximal inhibitory concentration: 1.65 ug/mL
For compound 4 the middle estimate is 4.7-fold (0.67 log units) below the measured one; measured number outside the range, above it.
By their numbers in this assay, from the lowest: compound 3; then compounds 1 and 2 (each within the scatter of the next); then compound 4.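

In this assay, inverting this one ring stereocentre gives a 9.7-fold higher number from compound 3 to compound 4 (0.99 log units; beyond the scatter), while the single inversion at a different ring stereocentre gave a 3.3-fold lower number from compound 1 to compound 3 (0.52 log units; beyond the scatter). The change also puts compound 4 clear of the other two, with a 2.1-fold higher number from compound 2 to compound 4 (0.32 log units; beyond the scatter) and a 2.9-fold higher number from compound 1 to compound 4 (0.47 log units; beyond the scatter), which makes it the weakest of the four. This large step arises with no change in atoms or bonds: the fact that compounds 3 and 4 differ only in the configuration as drawn

Going by these compounds, whether the same inversion gives a step of this size with a shorter chain or an added carboxylic acid stays open. The reason for its size also stays open.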